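Bromo to methoxy on the hydroxyphenyl arm of two cores

The source may hold more compounds than are shown below. What is called first, only, known or untested is meant among the compounds shown, and "the series" means these compounds.

Measured so far:
compound 1, `COc1ccc(/C=C/C(=O)C(=Cc2cc(Br)c(O)c(OC)c2)C(=O)/C=C/c2ccc(OC)cc2OC)c(OC)c1`, gives 1780 nM in a functional assay on CNE-2 cells (Homo sapiens) for antiproliferative activity, read by sulforhodamine B assay, with a stated time of 48 h; a lower number here means a stronger inhibitor, a higher number a weaker inhibitor
compound 2, `COc1ccc(/C=C/C(=O)C(=Cc2cc(OC)c(O)c(OC)c2)C(=O)/C=C/c2ccc(OC)cc2OC)c(OC)c1`, gives 850 nM
compound 3, `COc1cc(OC)c(/C=C/C(=O)C(=Cc2cc(Br)c(O)c(OC)c2)C(=O)/C=C/c2c(OC)cc(OC)cc2OC)c(OC)c1`, gives 1320 nM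

Compound 1 and compound 2 share one core; compound 3 and the unmeasured compound 4, `COc1cc(OC)c(/C=C/C(=O)C(=Cc2cc(OC)c(O)c(OC)c2)C(=O)/C=C/c2c(OC)cc(OC)cc2OC)c(OC)c1`, share another. The difference between the two cores is not broken down here.

For the measured compounds named here, the single change from compound 1 to compound 2 is methoxy in place of bromo on an aromatic carbon. It made a 2.1-fold lower number from compound 1 to compound 2 (0.32 log units; beyond the scatter), a shift that lies beyond the usual scatter. The change from compound 3 to compound 4 is methoxy in place of bromo on an aromatic carbon. The surroundings of the changed carbon read the same word for word in both pairs, so this is the same change carried onto the second core.

Compound 3 lies within the scatter of both compound 1 and compound 2, so no ordering of the three is read from these numbers alone.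

Going by the values given here, with only one matched pair to go on, the step from compound 3 to compound 4 is expected at about a 2.0-fold lower number from compound 3 to compound 4 (0.31 log units; beyond the scatter), because the same change gave a 2.1-fold lower number from compound 1 to compound 2 (0.32 log units; beyond the scatter). The expectation for compound 4 therefore lands near 650 nM in this assay, with an estimated range from 350 nM to 1300 nM that is kept wide because a single precedent step a 2.1-fold lower number from compound 1 to compound 2 (0.32 log units; beyond the scatter) does not fix how far the change carries on a different core.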

Compound 4, half-maximal inhibitory concentration: 680 nM
Compound 4: middle estimate off by 1.0-fold (0.02 log units), on the low side; the range from low to high includes it.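

In this assay, the change from 3-bromo-4-hydroxy-5-methoxyphenyl to 4-hydroxy-3,5-dimethoxyphenyl on the second core gives a 1.9-fold lower number from compound 3 to compound 4 (0.29 log units; within the scatter), so this step taken alone does not clear the usual scatter. Set beside the step on the first core, its size cannot be told apart from the earlier one, and both steps point the same way, which fits the change carrying over between these two cores with little loss of size: the same change on two cores in this assay, a 2.1-fold lower number (0.32 log units; beyond the scatter) from compound 1 to compound 2 and a 1.9-fold lower number (0.29 log units; within the scatter) from compound 3 to compound 4, 1.1-fold (0.03 log units) apart, within the scatter of two such steps This rests on one matched pair per core, so it shows agreement between two cores only; it does not show that the change would carry to any other core, and it does not explain why the methoxy compounds give the lower numbers.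

Only bromo and methoxy are shown on this aromatic carbon, which leaves open how a chloro group, an ethoxy group or an amine in the same place would read in this assay. Also open, going by these compounds, is whether the step would keep its size if the hydroxy group on the same ring were replaced by another group, such as a methoxy group or a carboxylic acid.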